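Swapping an aryl group on a fused triazole core

A few compounds are considered here, and "the series" means these few. Any claim that something is new, unique, unknown or untested is made for them only; others in the source may bear on it.

Measured compounds:
Compound 1 `COc1ccc(Cl)c(-c2nnc3sc(Cc4c(C)[nH]c5ccc(OC)cc45)nn23)c1` gives 26.1%.
Compound 2 `COc1ccc2[nH]c(C)c(Cc3nn4c(-c5ccoc5C)nnc4s3)c2c1` gives 29.4%.
Compound 3 `COc1ccc(Cl)c(-c2nnc3sc(Cc4c[nH]c5ccccc45)nn23)c1` gives 21.4%.

These three values come from a functional assay on the whole organism (strain Wistar Albino) for inhibition, with Rattus norvegicus as the target, read by paw edema, with a stated time of 3 h, at a dose of 20 mg/kg; a lower number here means less inhibition, a higher number more inhibition at the dose given (going by the name of the read-out). Compound 1 and compound 2 share one core, and compound 3 has a different core; how the two cores differ is not broken down here. Compound 1 and compound 2 differ in one place only, (2-methylfuran-3-yl in place of 2-chloro-5-methoxyphenyl on an aromatic carbon). This change made a step of a number 3.3 percentage points higher from compound 1 to compound 2 (within the scatter).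

Compound 4 `Cc1occc1-c1nnc2sc(Cc3c[nH]c4ccccc34)nn12` has not yet been measured. It differs from compound 3 in one place, (2-methylfuran-3-yl in place of 2-chloro-5-methoxyphenyl on an aromatic carbon). The surroundings of that place are the same as in the change from compound 1 to compound 2, so the two changes are the same. In this assay the step from compound 3 to compound 4 is expected to be of a size like a number 3.3 percentage points higher from compound 3 to compound 4 (within the scatter), resting on the earlier step, a number 3.3 percentage points higher from compound 1 to compound 2 (within the scatter), and on the value of compound 3, 21.4%. On that basis compound 4 is estimated to give 24.7%, with a likely range from 15% to 35%.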

Compound 4, a percentage reported as inhibition, in the whole organism at one dose (the size of the read-out at that dose, not a potency): 26.5%
The estimate for compound 4 lay 1.8 percentage points below the measured number; low and high end bracket the measured number.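

In this assay, putting 2-methylfuran-3-yl in place of 2-chloro-5-methoxyphenyl on the core of compound 3 gave a step of a number 5.1 percentage points higher from compound 3 to compound 4 (within the scatter), and this sits close to the same change on the other core: the same change on two cores in this assay, a number 3.3 percentage points higher (within the scatter) from compound 1 to compound 2 and a number 5.1 percentage points higher (within the scatter) from compound 3 to compound 4, 1.8 percentage points apart, within the scatter of two such steps

So the swap behaved alike on both cores, and the data separate no core effect on it. This does not show that the swap itself raises the inhibition of paw edema, since each step on its own lies within the scatter, and two cores cannot show that the same would hold on a third.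

The compounds shown carry only these two groups at this place, so it remains open whether an amine, a carboxylic acid or a longer alkyl chain on that aromatic carbon would give a step beyond the scatter. Each compound is also seen at one dose and one time, which leaves open how the numbers would look at other doses or times.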